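Aryl hydrazone variation on a shared urea core

The source may hold more compounds than are shown below. What is called first, only, known or untested is meant among the compounds shown, and "the series" means these compounds.

Measured so far:
compound 1 `COc1ccc(OC)c(/C=N/NC(=O)Nc2ccc(Oc3ccnc(-c4nncn4CCN(C)C)c3)c(F)c2)c1`: 1950 nM
compound 2 `CN(C)CCn1cnnc1-c1cc(Oc2ccc(NC(=O)N/N=C/c3ccc(F)cc3Cl)cc2F)ccn1`: 1120 nM
compound 3 `CN(C)CCn1cnnc1-c1cc(Oc2ccc(NC(=O)N/N=C/c3ccc(O)c(O)c3)cc2F)ccn1`: > 100000 nM

In a functional assay on A549 cells (Homo sapiens) for cytotoxicity, read by MTT assay, with a stated time of 72 h (on this read-out higher numbers stand for weaker inhibition and lower numbers for stronger inhibition), compound 1 gives 1950 nM and stands as the highest of the two plain numbers, with compound 2 nearest: a 1.7-fold lower number from compound 1 to compound 2 (0.24 log units; within the scatter). Compound 3 gives only a limit in this assay, > 100000 nM, and that limit is the limit of > 100000 nM in this assay, at which 1 of the 3 values shown sits. From that pair of steps the picture is uneven: an at least 51-fold higher number from compound 1 to compound 3 (1.70 log units; beyond the scatter) and an at least 89-fold higher number from compound 2 to compound 3 (1.95 log units; beyond the scatter) are both large losses, while the swap between compound 1 and compound 2 stays within the scatter.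

Compound 4 `CN(C)CCn1cnnc1-c1cc(Oc2ccc(NC(=O)N/N=C/c3c[nH]c4ccccc34)cc2F)ccn1` is not yet measured. Its change from compound 1 is 1H-indol-3-yl in place of 2,5-dimethoxyphenyl on a carbon with a double bond to nitrogen. For the measured compounds named here, the steps that bear on it are the three above, all on the same carbon with a double bond to nitrogen. The step from compound 1 to compound 2 shows that one aromatic group can replace another there with no change beyond the scatter; the steps to compound 3 show that a 3,4-dihydroxyphenyl group is not tolerated. The 1H-indol-3-yl group carries one hydrogen-bond donor and keeps a six-membered aromatic ring of carbon only, so the expected step is modest: a 1.3-fold lower number from compound 1 to compound 4 (0.11 log units; within the scatter). Compound 4 is therefore estimated at 1500 nM, with a range from 400 nM to 6000 nM.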

Compound 4, half-maximal inhibitory concentration: 820 nM
Estimate against measurement, compound 4: 1.8-fold (0.26 log units) above; the measured number falls inside the stated range.
By their numbers in this assay, from the lowest: compounds 4, 2 and 1 (each within the scatter of the next, the first and the last beyond it). At a limit, above all of these: compound 3.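

In this assay, for the compounds shown here, the 1H-indol-3-yl group is the first replacement at this carbon with a double bond to nitrogen to improve on the 2,5-dimethoxyphenyl group beyond the scatter, with a 2.4-fold lower number from compound 1 to compound 4 (0.38 log units; beyond the scatter). That gain does not separate it from the 2-chloro-4-fluorophenyl group, since the comparison gives a 1.4-fold lower number from compound 2 to compound 4 (0.14 log units; within the scatter) and these two cannot be ordered, so two quite different aromatic groups are accommodated at this place with similar results. The 1H-indol-3-yl group also carries a hydrogen-bond donor and still shows an at least 120-fold lower number from compound 3 to compound 4 (2.08 log units; beyond the scatter), so a donor on the aromatic group does not by itself go with the loss seen for the 3,4-dihydroxyphenyl group.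

From the compounds shown here alone, compound 3 is held only as a limit and not as a number, so the full size of its loss stays open: the limit of > 100000 nM in this assay, at which 1 of the 4 values shown sits. Also open, going by these compounds, is whether a single hydroxyl, a primary amine or a carboxylic acid on the phenyl group at this place would behave like the 3,4-dihydroxyphenyl group or like the 1H-indol-3-yl group.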